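A few compounds are considered here, and "the series" means these few. Any claim that something is new, unique, unknown or untested is made for them only; others in the source may bear on it.

Compound 1 `O=c1[nH]cc(S(=O)(=O)Nc2ccc(-c3cn(-c4ccccc4F)nn3)cc2)c(=O)[nH]1`; compound 2 `O=c1[nH]cc(S(=O)(=O)Nc2ccc(-c3cn(-c4cccc(F)c4)nn3)cc2)c(=O)[nH]1`.

In a functional assay on SGC-7901 cells (Homo sapiens) for antiproliferative activity, read by MTT assay, with a stated time of 24 h (on this read-out higher numbers stand for weaker inhibition and lower numbers for stronger inhibition), compound 1 gives 7270 nM. For compound 2 this assay reports only a limit, > 20000 nM. The single measured step, an at least 2.7-fold higher number from compound 1 to compound 2 (0.43 log units; beyond the scatter), is bounded by the limit of > 20000 nM in this assay, at which 1 of the 2 values shown sits, so compound 2 stands at the weak end of what is shown. Compound 3 `O=c1[nH]cc(S(=O)(=O)Nc2ccc(-c3cn(-c4ccc(F)cc4)nn3)cc2)c(=O)[nH]1` differs from compound 2 by 4-fluorophenyl in place of 3-fluorophenyl on an aromatic nitrogen. Among the compounds with values here, no measured step covers this change, so no step beyond the scatter is expected in this assay, and the estimated step is an at least 1.3-fold lower number from compound 2 to compound 3 (0.12 log units; that floor lies within the scatter). Compound 3 is therefore expected at 15000 nM, with a range from 5000 nM to 40000 nM.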

Compound 3, half-maximal inhibitory concentration: > 20000 nM
Compound 3 gave a limit, no number (the forecaster's own chance of this, stated with the estimate: 45%); at least 1.3-fold (0.12 log units) between middle value and limit.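

In this assay, 4-fluorophenyl in place of 2-fluorophenyl on this aromatic nitrogen gives an at least 2.7-fold higher number from compound 1 to compound 3 (0.43 log units; beyond the scatter), so a second fluorophenyl isomer also ends at a limit rather than a number. Compound 2 and compound 3 both report limits, so the step between them cannot be read and their two groups cannot be ordered. Among the three compounds, only compound 1, with 2-fluorophenyl, gives a number, and the weak end now holds two compounds: the limit of > 20000 nM in this assay, at which 2 of the 3 values shown sit.

On these data alone, the actual numbers for compound 2 and compound 3 stay open. Also open, as far as these compounds go, is whether 2-chlorophenyl, 2-methoxyphenyl or unsubstituted phenyl on the same nitrogen would give a readable number.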